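Urea nitrogen substituent: benzyl exchanged for phenyl

The source may hold more compounds than are shown below. What is called first, only, known or untested is meant among the compounds shown, and "the series" means these compounds.

For the measured compounds named here, in a functional assay on HEK293T cells for agonist activity at histamine H2 receptor (Homo sapiens), read by beta-arrestin recruitment (on this read-out higher numbers stand for an effect only at larger amounts of compound and lower numbers for an effect already at smaller amounts), compound 2 `Cc1nc(N)sc1CCCN/C(N)=N/C(=O)NCc1ccccc1` gives 100 nM, the upper of the two numbers measured so far; compound 1 `CCCCCCNC(=O)/N=C(\N)NCCCc1sc(N)nc1C` gives 85.1 nM, and the step of a 1.2-fold higher number from compound 1 to compound 2 (0.07 log units; within the scatter) does not separate the two. Compound 3 `Cc1nc(N)sc1CCCN/C(N)=N/C(=O)Nc1ccccc1` differs from compound 2 by phenyl in place of benzyl on an amide-type nitrogen. Going by the values given here, the single measured step concerns the same amide-type nitrogen but a different exchange, so no directly comparable precedent exists; the one nearby change left this assay essentially unmoved. A similarly small shift is expected, a 1.5-fold higher number from compound 2 to compound 3 (0.18 log units; within the scatter). Compound 3 is therefore estimated at 150 nM, within 40 nM to 600 nM.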

Compound 3, half-maximal effective concentration: 3390 nM
Estimate against measurement, compound 3: 23-fold (1.35 log units) below, and the stated range ends below it.
By their numbers in this assay, from the lowest: compounds 1 and 2 (each within the scatter of the next); then compound 3.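

In this assay this nitrogen turns out not to be indifferent to its substituent: phenyl in place of benzyl on the amide-type nitrogen gives a 34-fold higher number from compound 2 to compound 3 (1.53 log units; beyond the scatter) and phenyl in place of hexyl gives a 40-fold higher number from compound 1 to compound 3 (1.60 log units; beyond the scatter). An aromatic ring as such is not what separates these compounds, since compound 2 carries one too; the benzylamino to anilino change alone carries the whole rise. Nothing at hand accounts for this rise.

Open, from the compounds shown here alone, is how a phenethyl group or a cyclohexyl group on the same nitrogen would read out, and whether substituents on the phenyl ring of compound 3 shift its number.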